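Swapping the 4-Cyanophenyl Arm for 3-Fluorophenyl

The compounds below may be only part of what the source reports. "The series", "measured", "known", "first", "only" and "open" are said of these compounds alone.

Three compounds have been measured in a functional assay on KB cells (Homo sapiens) for inhibition, with a stated time of 72 h; on this read-out lower numbers stand for stronger inhibition and higher numbers for weaker inhibition:

compound 1 `COc1ccc(S(=O)(=O)N2CCc3cccc(-c4ccc(C#N)cc4)c32)cc1` — 31.1 nM
compound 2 `COc1ccc(S(=O)(=O)N2CCc3cccc(-c4ccc(F)nc4)c32)cc1` — 143 nM
compound 3 `COc1ccc(S(=O)(=O)N2CCc3cccc(-c4cc(OC)c(OC)c(OC)c4)c32)cc1` — 3690 nM

Compound 1 has the lowest number of the three, meaning the strongest inhibition. The nearest to it is compound 2, reached by the step of a 4.6-fold higher number from compound 1 to compound 2 (0.66 log units; beyond the scatter). Compound 3 is the furthest away: with 3690 nM it lies far above compound 1, well beyond the scatter.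

Compound 4 `COc1ccc(S(=O)(=O)N2CCc3cccc(-c4cccc(F)c4)c32)cc1` has not yet been measured. It differs from compound 1 in one place: 3-fluorophenyl in place of 4-cyanophenyl on an aromatic carbon. Among the measured compounds shown here, the only measured step that bears on this is a 4.6-fold higher number from compound 1 to compound 2 (0.66 log units; beyond the scatter), in which a fluorine-bearing ring likewise replaced the 4-cyanophenyl and the number rose modestly. Compound 4 also gives up the single hydrogen-bond acceptor that the 4-cyanophenyl carried, so a modest rise beyond the scatter is expected in this assay, roughly a 3.5-fold higher number from compound 1 to compound 4 (0.55 log units; beyond the scatter). Compound 4 is therefore estimated at 110 nM, with a range of 35 nM to 400 nM.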

Compound 4, half-maximal inhibitory concentration: 98.5 nM
Compound 4: the middle estimate sits 1.1-fold (0.05 log units) above what was measured; the measured number falls inside the stated range.
By their numbers in this assay, from the lowest: compound 1; then compounds 4 and 2 (each within the scatter of the next); then compound 3.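

In this assay a second ring in place of the 4-cyanophenyl gives a comparable cost: the change is a 3.2-fold higher number from compound 1 to compound 4 (0.50 log units; beyond the scatter). The two fluorine-bearing rings also stay close to each other, with a 1.5-fold lower number from compound 2 to compound 4 (0.16 log units; within the scatter), so this assay does not separate them. Compound 1 therefore stays lowest of the compounds shown, and it is also the only one with a nitrile. Nothing available explains why the number rises when the 4-cyanophenyl leaves.

Still open, as far as these compounds go, is whether the nitrile itself matters or its place on the ring, since compound 4 changes both the group and where it sits; 3-cyanophenyl and 4-fluorophenyl would pull these two apart. From the compounds shown here alone, how an amine or a carboxylic acid on this ring would behave also remains unknown.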